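Tetralin imidazole sulfonamides: hydroxy to chloro swap

The compounds below may be only part of what the source reports. "The series", "measured", "known", "first", "only" and "open" are said of these compounds alone.

Measured so far in an assay on isolated protein for binding affinity to Alpha-1A adrenergic receptor (Rattus norvegicus), read by radioligand binding; on this read-out higher numbers stand for weaker inhibition and lower numbers for stronger inhibition:
compound 1, `O=S(=O)(Nc1cccc2c1CCCC2c1c[nH]cn1)C1CC1`, 537 nM
compound 2, `CCS(=O)(=O)Nc1cc(C2CCCCC2)cc2c1CCCC2c1c[nH]cn1`, 269 nM
compound 3, `CS(=O)(=O)Nc1ccc(O)c2c1CCCC2c1c[nH]cn1`, 708 nM

Compound 3 holds the highest number of the three. Its gap to compound 1 lies within the usual scatter, so no order between those two can be read; its gap to compound 2 lies beyond the scatter, and compound 2 shows the lower number.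

Compound 4, `CS(=O)(=O)Nc1ccc(Cl)c2c1CCCC2c1c[nH]cn1`, is the next compound for this assay. Relative to compound 3 the change is chloro in place of hydroxy on an aromatic carbon. Going by the values given here, no measured pair isolates this swap, so there is no precedent step to lean on. The expectation is a modest step from compound 3 to compound 4 of a 1.6-fold lower number from compound 3 to compound 4 (0.20 log units; within the scatter), towards a somewhat lower number, quite possibly not beyond the scatter. Compound 4 is therefore estimated at 450 nM, with a range from 150 nM to 1400 nM.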

Compound 4, inhibition constant: 447 nM
Compound 4: middle estimate off by 1.0-fold (0.00 log units), on the high side, within the range that was stated.
By their numbers in this assay, from the lowest: compounds 2, 4, 1 and 3 (each within the scatter of the next, the first and the last beyond it).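

Going by these compounds alone, on the aromatic carbon para to the methanesulfonamido group, chloro in place of hydroxy gives a 1.6-fold lower number from compound 3 to compound 4 (0.20 log units; within the scatter) in this assay, the first isolated step at this position, and it stays within the scatter. The swap removes the hydrogen-bond donor and acceptor counted for hydroxy, yet the number does not move beyond the scatter. Nothing available bears on the reason for this result.

Going by these compounds, whether an amine or a methoxy group on this carbon would give a step beyond the scatter remains open.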